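From 4-chlorophenyl to 3-bromophenyl on a sulfonyl sulfur

This account rests on a few compounds, and the source may have more. Where it says the series, first, only, none or still open, it means among the compounds named here.

Of the compounds shown here, three that share a core have been measured so far in a functional assay on HL-60 cells (Homo sapiens) for cytotoxicity, read by MTT assay (a higher number here means a weaker inhibitor, a lower number a stronger inhibitor), for comparison. Compound 3 `CC(NS(=O)(=O)c1ccc(Cl)cc1)C1=CC(=O)c2c(O)ccc(O)c2C1=O` stands at 250 nM as the starting point here. Compound 2 `COc1ccc(S(=O)(=O)NC(C)C2=CC(=O)c3c(O)ccc(O)c3C2=O)c(OC)c1` stands at 500 nM and lies within the scatter of compound 3. Compound 1 `CC(C)C(NS(=O)(=O)c1cccc(Br)c1)C1=CC(=O)c2c(O)ccc(O)c2C1=O` stands at 790 nM and lies beyond the scatter, with a higher number than compound 3.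

Compound 4 `CC(NS(=O)(=O)c1cccc(Br)c1)C1=CC(=O)c2c(O)ccc(O)c2C1=O` carries 3-bromophenyl in place of 4-chlorophenyl on a sulfonyl sulfur, and the count for that swap reads 3-bromophenyl in place of 4-chlorophenyl on a sulfonyl sulfur with the rest of the structure unchanged.

Going by the values given here, no measured pair isolates this exact swap. The closest evidence is a change at the same place: a 2.0-fold lower number from compound 2 to compound 3 (0.30 log units; within the scatter) for 4-chlorophenyl in place of 2,4-dimethoxyphenyl, a step that stays within the scatter. Compound 1 at 790 nM also carries 3-bromophenyl, but it differs from compound 4 at another place as well, so it is only a weak hint towards a higher number.

The estimated move is a 1.4-fold higher number from compound 3 to compound 4 (0.15 log units; within the scatter) and this expected change is slightly upward, most likely within the scatter. In this assay compound 4 is expected at 350 nM within an estimated range of 150 nM to 800 nM on measurement.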

Compound 4, half-maximal inhibitory concentration: 160 nM
Estimate against measurement, compound 4: 2.2-fold (0.34 log units) above; measured number inside the range.
By their numbers in this assay, from the lowest: compounds 4, 3, 2 and 1 (each within the scatter of the next, the first and the last beyond it).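

In this assay the swap to 3-bromophenyl in place of 4-chlorophenyl on a sulfonyl sulfur gives a 1.6-fold lower number from compound 3 to compound 4 (0.19 log units; within the scatter) and so cannot be told apart from ordinary repeat-to-repeat variation. The group at this place can still make a measurable difference: 3-bromophenyl in place of 2,4-dimethoxyphenyl gives a 3.1-fold lower number from compound 2 to compound 4 (0.49 log units; beyond the scatter) and clears the scatter, whereas 4-chlorophenyl in place of 2,4-dimethoxyphenyl gives a 2.0-fold lower number from compound 2 to compound 3 (0.30 log units; within the scatter) and does not. Compound 4 also gives a clean reading at a second place, with the 3-bromophenyl group held fixed: methyl in place of isopropyl on a saturated chain carbon bound to a double-bonded ring carbon and a sulfonamide nitrogen gives a 4.9-fold lower number from compound 1 to compound 4 (0.69 log units; beyond the scatter) and is likewise a modest step beyond the scatter.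

No measurement offered here accounts for the size of any of these steps. Still open, going by these compounds, is how this assay would respond to an amine or a carboxylic acid on the phenyl ring, or to an ethyl group in place of the methyl on that chain carbon.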